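This account rests on a few compounds, and the source may have more. Where it says the series, first, only, none or still open, it means among the compounds named here.

The series shares one core, varied at a single aromatic carbon. Compound 1 `CCCCCC#Cc1cc2cn(COCCO)c(=O)nc2o1` carries hept-1-yn-1-yl there, compound 2 `CCCCCCCCCCc1cc2cn(COCCO)c(=O)nc2o1` decyl, and compound 3 `O=c1nc2occc2cn1COCCO` hydrogen. Going by the values given here, in a functional assay on HEL cells (Homo sapiens), read by microscopy (a higher number here means that more compound is tolerated, a lower number that less compound is tolerated), compound 2 gives 400000 nM, the only plain number among the three values shown. Compound 1 reaches only a limit of the assay, >= 100000 nM. Compound 3 likewise reaches only a limit, > 400000 nM. The step that the two limits leave unreadable from compound 1 to compound 3 is thus not readable in size. Compound 4 `CCCCCCCCCCCc1cc2cn(COCCO)c(=O)nc2o1` is not yet measured; it differs from compound 2 by methyl in place of hydrogen on a saturated chain carbon, ten or more bonds along the chain from an aromatic carbon. Among the compounds with values here, no measured step touches the far end of the chain, and the two limits, the limit of > 400000 nM in this assay, at which 1 of the 3 values shown sits, and (the limit of >= 100000 nM in this assay, at which 1 of the 3 values shown sits), mark only where the assay stops reading. Compound 2 is the sole anchor, and no step beyond the scatter is expected in this assay, so the expected step is no change at the digits printed from compound 2 to compound 4 (within the scatter). Compound 4 is estimated at 400000 nM, between 200000 nM and 800000 nM, with a real chance that only a limit is returned.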

Compound 4, minimum cytotoxic concentration: 80000 nM
Compound 4: middle estimate off by 5.0-fold (0.70 log units), on the high side; measured number below the stated range.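

In this assay the far end of the chain proves able to move the read-out: methyl in place of hydrogen on a saturated chain carbon, ten or more bonds along the chain from an aromatic carbon, gives a 5.0-fold lower number from compound 2 to compound 4 (0.70 log units; beyond the scatter) and so a modest step beyond the scatter. Before this pair, the series held only one plain number and no readable step, so nothing yet showed that a change this far out could lower the tolerated concentration. Nothing available here points to a cause for this step.

The steps that rest on limits cannot be read, so no trend with chain length can be drawn across the series. On these data alone, whether a longer chain, or an amine or a carboxylic acid at the chain end, would shift this assay further remains open.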